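Swapping the triazole for a methylpyrazole on the shared core

A few compounds are considered here, and "the series" means these few. Any claim that something is new, unique, unknown or untested is made for them only; others in the source may bear on it.

Measured compounds:
Compound 1, `CCCn1ncnc1-c1ccccc1NCC1=NCCN1`: in an in vitro functional assay on cells (Fibroblast) for agonist activity at Alpha-1D adrenergic receptor (Homo sapiens) (a higher number here means that more compound is needed for the effect, a lower number that less compound is needed), compound 1 gives 251 nM.
Compound 2, `c1ccc(-c2nc[nH]n2)c(NCC2=NCCN2)c1`: in this assay compound 2 gives 3.98 nM.
Compound 3, `Cc1ccc(-c2ccccc2NCC2=NCCN2)n1C`: in this assay compound 3 gives only a limit, < 100000 nM.

Compound 2 holds the lowest of the two numbers reported in this assay; the nearest is compound 1, whose number lies higher by a margin well beyond the scatter of repeated measurements. The value for compound 3 is a limit of the assay the limit of < 100000 nM in this assay, at which 1 of the 3 values shown sits, and not a number, so it cannot be ranked against the others.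

Compound 4, `Cn1cc(-c2ccccc2NCC2=NCCN2)cn1`, has not yet been measured. It differs from compound 2 in a single place: 1-methyl-1H-pyrazol-4-yl in place of 1H-1,2,4-triazol-3-yl on an aromatic carbon. For the measured compounds named here, no step between two measured compounds that differ in only one place is available, so the size of the step to compound 4 can only be expected, not read off. Compound 4, like compound 1, has no hydrogen-bond donor on its five-membered ring, and in this assay compound 1 gives 251 nM. On that basis the step of a 50-fold higher number from compound 2 to compound 4 (1.70 log units; beyond the scatter) is expected to be an increase beyond the scatter. For compound 4 the expected value is 200 nM, with a range from 30 nM to 1500 nM.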

Compound 4, half-maximal effective concentration: < 100000 nM
Compound 4 ended at the assay's limit (the forecaster's own chance of this, stated with the estimate: 10%); the middle value lies beyond the limit too.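

In this assay compound 4 gives only a limit, < 100000 nM. For the compounds shown here, no step from compound 2 to compound 4 can be read from this result, and the value is not alone there: the limit of < 100000 nM in this assay, at which 2 of the 4 values shown sit. The compounds shown leave open how large that step is, and whether it follows from the lost hydrogen-bond donor or from the change of ring.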